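The compounds below may be only part of what the source reports. "The series", "measured", "known", "first", "only" and "open" are said of these compounds alone.

Measured so far in this assay:
compound 1 `COc1ccc(Cn2cc(CO/N=C/c3c(-c4ccccc4)nc4c(C)cccn34)nn2)cc1`: 100 mg/kg
compound 2 `COc1ccc(Cn2cc(CO/N=C/c3c(-c4ccc(C)cc4)nc4c(C)cccn34)nn2)cc1`: 100 mg/kg
compound 3 `COc1ccc(Cn2cc(CO/N=C/c3c(-c4ccc(C)cc4)nc4ccc(Br)cn34)nn2)cc1`: 40 mg/kg

In a functional assay on the whole organism (strain NMRI) with Mus musculus as the target, with a stated time of 4 h (on this read-out higher numbers stand for an effect only at larger amounts of compound and lower numbers for an effect already at smaller amounts), compound 3 stands lowest; its nearest neighbour compound 1 lies beyond the scatter above it. The core of compound 3 differs from the core of compound 2 in a way that is not broken down here. Within the core of compound 2 the change hydrogen in place of methyl on an aromatic carbon gave no change at the digits printed from compound 2 to compound 1 (within the scatter). Compound 4 `COc1ccc(Cn2cc(CO/N=C/c3c(-c4ccccc4)nc4ccc(Br)cn34)nn2)cc1` carries the same change on the core of compound 3, (hydrogen in place of methyl on an aromatic carbon), with identical surroundings at the place. Because the step of no change at the digits printed from compound 2 to compound 1 (within the scatter) stayed within the scatter, the step of no change at the digits printed from compound 3 to compound 4 (within the scatter) is expected to be flat as well, resting on that single earlier pair. Compound 4 is therefore estimated at 40 mg/kg in this assay, between 20 mg/kg and 80 mg/kg.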

Compound 4, minimum effective dose: 40 mg/kg
For compound 4 middle estimate and measured number coincide at the digits printed, within the range that was stated.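

In this assay, the change from 4-methylphenyl to phenyl gave no change at the digits printed from compound 3 to compound 4 (within the scatter), and set beside the earlier step on the other core it reads the same: the same change on two cores in this assay, no change at the digits printed (within the scatter) from compound 2 to compound 1 and no change at the digits printed (within the scatter) from compound 3 to compound 4, 1.0-fold (0.00 log units) apart, within the scatter of two such steps

On these two cores the change therefore carries over as a flat step, and the methyl can go without a shift that stands out from the scatter in this read-out. Among these compounds, this rests on only two pairs, both flat, so it does not show that a step of real size would carry over in the same way, nor that the flat step would hold on a further core.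

Open, from the compounds shown here alone, is what a group other than methyl would do at this place on the six-membered aromatic ring, for instance an amine, a carboxylic acid or a longer chain. Also open, going by these compounds, is whether such a group would give the same step on both cores.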